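A few compounds are considered here, and "the series" means these few. Any claim that something is new, unique, unknown or untested is made for them only; others in the source may bear on it.

Compound 1 `Cc1nnc(SCc2cc(=O)c3ccccc3o2)o1` was tested in a functional assay on LM7 cells (Homo sapiens) for cytotoxicity, read by MTT assay, with a stated time of 72 h; on this read-out lower numbers stand for stronger inhibition and higher numbers for weaker inhibition. In this assay compound 1 gives > 25000 nM, which is a limit of the assay rather than a measured number. Two companions were run in the same way. Compound 2 `Cc1cc(C)n2nc(SCc3nnc(SCc4cc(=O)c5ccccc5o4)n3-c3ccccc3)nc2n1` is a larger molecule built around the same core. In this assay compound 2 gives > 25000 nM, again a limit. Compound 3 `Cc1cc(O)cc2oc(=O)cc(CSc3nc4ccccc4s3)c12` carries a different core. In this assay compound 3 gives > 25000 nM, also a limit. Going by the values given here, compound 1 therefore stands exactly where the whole set stands: at the limit of > 25000 nM in this assay, at which 3 of the 3 values shown sit, with no compound returning an actual number.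

Compound 4 `Nc1nnc(SCc2cc(=O)c3ccccc3o2)s1` has not yet been measured. It differs from compound 1 in a single place: 5-amino-1,3,4-thiadiazol-2-yl in place of 5-methyl-1,3,4-oxadiazol-2-yl on a sulfur. Among the compounds with values here, no pair of measured compounds differing in one place exists, so the size of this step cannot be read from the numbers. The three limits show only that none of the differences among compound 1, compound 2 and compound 3 produced a measurable value. The step that the limit leaves unreadable from compound 1 to compound 4 is expected to be none beyond the scatter, in either direction. Compound 4 is estimated at 30000 nM, with a range from 8000 nM to 100000 nM, and the assay will most likely again report only a limit.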

Compound 4, half-maximal inhibitory concentration: > 25000 nM
Compound 4: no number, only a limit (the forecaster's own chance of this, stated with the estimate: 75%); the middle value is on the limit's open side.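

Compound 4, like compound 1, returns only a limit, so the size of the step from compound 1 to compound 4 cannot be read. The whole set now rests at a single point: the limit of > 25000 nM in this assay, at which 4 of the 4 values shown sit. The compounds shown leave open whether any change to this structure would give an actual number in this assay.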